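Cyano for ethyl on the amide aryl of compound 3

This account rests on a few compounds, and the source may have more. Where it says the series, first, only, none or still open, it means among the compounds named here.

Three compounds have been measured in a functional assay on MDA-MB-231 cells (Homo sapiens) for antiproliferative activity, read by CCK-8 assay, with a stated time of 72 h; a lower number here means a stronger inhibitor, a higher number a weaker inhibitor:
Compound 1 `O=C(Nc1cccc(-c2oc3cc(-c4ccc(F)cc4)ccc3c(=O)c2O)c1)c1ccc(F)cc1` gives 16000 nM.
Compound 2 `COc1cccc(C(=O)Nc2cccc(-c3oc4cc(-c5ccc(F)cc5)ccc4c(=O)c3O)c2)c1` gives 9160 nM.
Compound 3 `CCc1ccc(C(=O)Nc2cccc(-c3oc4cc(-c5ccc(F)cc5)ccc4c(=O)c3O)c2)cc1` gives 9070 nM.

Compound 3 holds the lowest of the three numbers, but its distance to compound 2 and to compound 1 stays within the scatter, so no order among the three can be read from them. The steps seen so far are small: a 1.8-fold lower number from compound 1 to compound 3 (0.25 log units; within the scatter) and a 1.0-fold lower number from compound 2 to compound 3 (0.00 log units; within the scatter), and likewise a 1.7-fold lower number from compound 1 to compound 2 (0.24 log units; within the scatter). Every change tried so far on the amide aryl has left the number where it was.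

Compound 4 `N#Cc1ccc(C(=O)Nc2cccc(-c3oc4cc(-c5ccc(F)cc5)ccc4c(=O)c3O)c2)cc1` differs from compound 3 in one place: cyano in place of ethyl on an aromatic carbon. Going by the values given here, no measured step involves a cyano group, so the expectation rests only on the observation that the three variations of this aryl have stayed within the scatter. The step is therefore expected to be a 1.0-fold higher number from compound 3 to compound 4 (0.02 log units; within the scatter), with no clear direction. Compound 4 is accordingly estimated at 9500 nM, in the range 3500 nM to 26000 nM.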

Compound 4, half-maximal inhibitory concentration: 11600 nM
Estimate against measurement, compound 4: 1.2-fold (0.09 log units) below, within the range that was stated.
By their numbers in this assay, from the lowest: compounds 3, 2, 4 and 1 (each within the scatter of the next).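

In this assay, cyano on the amide aryl, para to a large group, brings in a triple bond and a hydrogen-bond acceptor where ethyl had neither, yet the result stays within the scatter, with a 1.3-fold higher number from compound 3 to compound 4 (0.11 log units; within the scatter). The comparisons with the other amides also stay within it, with a 1.3-fold higher number from compound 2 to compound 4 (0.10 log units; within the scatter) and a 1.4-fold lower number from compound 1 to compound 4 (0.14 log units; within the scatter), so nitrile joins fluoro, methoxy and ethyl without separating the four compounds. Nothing available bears on why this position shows so little response to these groups.

On these data alone, it remains open whether an amine, a carboxylic acid or a longer chain such as hexyl on this aryl would give a step beyond the scatter. As far as these compounds go, it is equally open whether replacing the 4-fluorophenyl group on the shared core would do so.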